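Benzyl Variation in a Platelet Inhibition Series

A few compounds are considered here, and "the series" means these few. Any claim that something is new, unique, unknown or untested is made for them only; others in the source may bear on it.

Compound 3 `CCOC(=O)c1ccc(-c2nn(Cc3cccc(F)c3)c3ccccc23)cc1` is the starting point of this step. In a functional assay on cells (Platelet, Homo sapiens) for inhibition (on this read-out lower numbers stand for stronger inhibition and higher numbers for weaker inhibition), compound 3 gives only a limit of the assay, > 10000 nM. Compound 1 `CCOC(=O)c1ccc(-c2nn(C)c3ccccc23)cc1` also reaches only a limit in this assay, > 10000 nM. Compound 2 `CCOC(=O)c1ccc(-c2nn(Cc3ccccc3Cl)c3ccccc23)cc1` likewise returns a limit, > 10000 nM. Accordingly the steps a step that the two limits leave unreadable from compound 1 to compound 2, a step that the two limits leave unreadable from compound 1 to compound 3 and a step that the two limits leave unreadable from compound 2 to compound 3 cannot be read in size or direction; the limit of > 10000 nM in this assay, at which 3 of the 3 values shown sit, sums up the situation. Compound 4 `CCOC(=O)c1ccc(-c2nn(Cc3ccc(OC)cc3)c3ccccc23)cc1` differs from compound 3 by 4-methoxyphenyl in place of 3-fluorophenyl on a saturated chain carbon bound to an aromatic nitrogen. The measured steps are neighbours of this change, each swapping the group on the same saturated chain carbon, yet none of them yields a size, so nothing about direction can be drawn from them. The step that the limit leaves unreadable from compound 3 to compound 4 is therefore estimated as none beyond the scatter. Because compound 3 stands at > 10000 nM, compound 4 is expected to give 15000 nM in this assay, within a range from 3000 nM to 60000 nM, and most probably to be reported only as a limit.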

Compound 4, half-maximal inhibitory concentration: > 10000 nM
Compound 4 was reported as a limit; the forecaster's own chance of this, stated with the estimate: 80%; the middle value does not contradict the limit.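

In this assay compound 4 gives only a limit, > 10000 nM. Its steps from compound 1, compound 2 and compound 3 cannot be read in size or direction. The compounds shown leave open how the groups on the saturated chain carbon rank against one another, with every reading at: the limit of > 10000 nM in this assay, at which 4 of the 4 values shown sit.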